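A few compounds are considered here, and "the series" means these few. Any claim that something is new, unique, unknown or untested is made for them only; others in the source may bear on it.

Of the compounds shown here, three sharing one core have been measured. Compound 1 `CC1=CC[C@@H]([C@@](C)(O)CCCC(C)(C)NC(=S)N/N=C\c2ccc(N(C)C)cc2)CC1` gives 14000 nM in a functional assay on MCF7 cells (Homo sapiens) for cytotoxicity, read by sulforhodamine B assay; a higher number here means a weaker inhibitor of growth, a lower number a stronger inhibitor of growth. Compound 2 `CC1=CC[C@@H]([C@@](C)(O)CCCC(C)(C)NC(=S)N/N=C\c2ccccc2[N+](=O)[O-])CC1` gives 18600 nM in this assay, and compound 3 `CC1=CC[C@@H]([C@@](C)(O)CCCC(C)(C)NC(=S)N/N=C\c2cccc([N+](=O)[O-])c2)CC1` gives 6720 nM. Compound 3 therefore stands at the lowest of the three numbers, the strongest inhibitor of growth among them: the step of a 2.1-fold lower number from compound 1 to compound 3 (0.32 log units; beyond the scatter) and the step of a 2.8-fold lower number from compound 2 to compound 3 (0.44 log units; beyond the scatter) both lie beyond the scatter, whereas the step of a 1.3-fold higher number from compound 1 to compound 2 (0.12 log units; within the scatter) does not.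

Compound 4 `CC1=CC[C@@H]([C@@](C)(O)CCCC(C)(C)NC(=S)N/N=C\c2ccccc2Cl)CC1` has not yet been measured. It differs from compound 3 in one place: 2-chlorophenyl in place of 3-nitrophenyl on a carbon with a double bond to nitrogen. Two of the measured steps bear on this change. Within the data shown here, the step of a 2.8-fold lower number from compound 2 to compound 3 (0.44 log units; beyond the scatter) shows that moving the nitro group from the 2-position of the phenyl ring to the 3-position lowered the number beyond the scatter; compound 4 returns to a 2-substituted phenyl, though with chlorine rather than nitro, a swap no measured pair tests. The step of a 1.3-fold higher number from compound 1 to compound 2 (0.12 log units; within the scatter) shows that a 2-nitrophenyl gave much the same number as a 4-(dimethylamino)phenyl. On that basis compound 4 is expected to show a modest rise, a 1.9-fold higher number from compound 3 to compound 4 (0.29 log units; within the scatter), landing near the numbers of compound 1 and compound 2. The estimate for compound 4 in this assay is 13000 nM, with a plausible range from 6000 nM to 30000 nM.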

Compound 4, concentration for 50% growth inhibition: 31200 nM
Compound 4: the middle estimate sits 2.4-fold (0.38 log units) below what was measured, outside the stated range (above it).
By their numbers in this assay, from the lowest: compound 3; then compounds 1, 2 and 4 (each within the scatter of the next, the first and the last beyond it).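

In this assay, chloro in place of nitro on an aromatic carbon, a swap the other compounds could not test, gives a 1.7-fold higher number from compound 2 to compound 4 (0.22 log units; within the scatter), so 2-chlorophenyl and 2-nitrophenyl cannot be told apart here. Neither group matches 3-nitrophenyl: the change from 3-nitrophenyl to 2-chlorophenyl gives a 4.6-fold higher number from compound 3 to compound 4 (0.67 log units; beyond the scatter), the largest step in the set, and 2-chlorophenyl in place of 4-(dimethylamino)phenyl gives a 2.2-fold higher number from compound 1 to compound 4 (0.35 log units; beyond the scatter), which leaves 3-nitrophenyl as the only group shown whose number lies beyond the scatter of all three others. Nothing measured here explains why these groups differ.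

Going by these compounds, whether the low number of compound 3 goes with the nitro group itself or with where it sits on the phenyl ring stays open, as chloro appears only in 2-chlorophenyl and nitro only in 2-nitrophenyl and 3-nitrophenyl. Also open, on these data alone, is how a methoxy group, a nitrile or a carboxylic acid on the phenyl ring would read, and whether a shorter chain in the shared core would move the number at all.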